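The source may hold more compounds than are shown below. What is called first, only, known or untested is meant among the compounds shown, and "the series" means these compounds.

Compound 1 `COc1cc([C@](O)(CCN(C)C)[C@@H](c2cc3cc(Br)ccc3nc2OC)c2cccc(OC)c2F)cc(OC(C)C)n1` is tested in an ADME assay on microsomes from liver (Homo sapiens) for metabolic stability (on this read-out higher numbers stand for fast clearance and lower numbers for slow clearance), where compound 1 gives 3.4 uL/min. Its companion compound 2 `COc1cc([C@](O)(CCN(C)C)[C@@H](c2cc3cc(Br)ccc3nc2OC)c2ccnc(OC)c2OC)cc(OC(C)C)n1` gives 6.4 uL/min in this assay; the step of a 1.9-fold higher number from compound 1 to compound 2 (0.27 log units; within the scatter) is within the scatter, so the two compounds cannot be ordered. Among the two measured numbers compound 1 holds the lowest value, but only by that small margin.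

The step now followed leads to compound 3 `CCSc1cc([C@](O)(CCN(C)C)[C@@H](c2cc3cc(Br)ccc3nc2OC)c2cccc(OC)c2F)cc(SCC)n1`. Relative to compound 1 the change is a group of 12 heavy atoms (9 carbon, 1 nitrogen, 2 sulfur; one six-membered aromatic ring with 1 hetero atom) in place of a group of 12 heavy atoms (9 carbon, 1 nitrogen, 2 oxygen; one six-membered aromatic ring with 1 hetero atom), on a saturated chain carbon bound to an oxygen on a saturated carbon and two saturated chain carbons. Among the compounds with values here, no measured step touches this part of the molecule: the single recorded step, from compound 1 to compound 2, concerns a different ring and is itself within the scatter, so it gives no guide to the size or direction of what this exchange may do in this assay. Compound 3 is therefore expected to lie near compound 1, with a 1.5-fold higher number from compound 1 to compound 3 (0.17 log units; within the scatter) as the estimated step and a wide range. The estimate for compound 3 is 5 uL/min, expected between 2 uL/min and 14 uL/min.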

Compound 3, intrinsic clearance in a liver preparation (reported as CLH), per the amount of preparation that the assay uses: 4.9 uL/min
Beside the measured number, compound 3's estimate is 1.0-fold (0.01 log units) above it; the measured number falls inside the stated range.
By their numbers in this assay, from the lowest: compounds 1, 3 and 2 (each within the scatter of the next).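

In this assay, within the data shown here, the group with 2 sulfur in place of the group with 2 oxygen gives a 1.4-fold higher number from compound 1 to compound 3 (0.16 log units; within the scatter), the first reading for this part of the molecule. The exchange keeps the count of 12 heavy atoms and the same counts of hydrogen-bond donors and acceptors, and the read-out cannot order the two compounds, so this single exchange at this position shows no measurable shift. Nothing available explains this outcome.

The compounds shown leave open whether exchanging only one of the two oxygen atoms for sulfur would give a similar reading. They also leave open whether an amine or a carboxylic acid on this six-membered aromatic ring would stay within the scatter of compound 1.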